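This account rests on a few compounds, and the source may have more. Where it says the series, first, only, none or still open, it means among the compounds named here.

Three compounds of this series have numbers in a functional assay on MCF7 cells (Homo sapiens) for antiproliferative activity, read by MTT assay, with a stated time of 48 h; a higher number here means a weaker inhibitor, a lower number a stronger inhibitor. Compound 1 `C#Cc1cccc(Nc2ncnc3sc(NC(=O)/C=C/c4ccccc4)cc23)c1` gives 38400 nM. Compound 2 `COc1ccc(/C=C/C(=O)Nc2cc3ncnc(Nc4ccc(F)c(Cl)c4)c3s2)cc1` gives 29100 nM in this assay. Compound 3 `O=C(/C=C/c1ccccc1)Nc1cc2c(Nc3ccc(F)c(Cl)c3)ncnc2s1` gives 14300 nM in this assay, the lowest of the three numbers; compound 2 stands nearest to it and compound 1 furthest, both beyond the scatter and both higher.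

Compound 4 `O=C(/C=C/c1ccccc1)Nc1cc2c(Nc3cccc(Cl)c3F)ncnc2s1` has not yet been measured in this assay. Its difference from compound 3 is 3-chloro-2-fluorophenyl in place of 3-chloro-4-fluorophenyl on a nitrogen on an aromatic ring; the two hold the same atoms, joined differently, and the change sits on the nitrogen attached to the shared core.

Going by the values given here, the only measured step at this position is a 2.7-fold lower number from compound 1 to compound 3 (0.43 log units; beyond the scatter), a different kind of swap in which the whole ring substituent changed. Among the compounds with values here, no measured pair moves a fluorine from one spot to another on an otherwise unchanged ring, so the size of such a shift is not established here. The numbers of compound 2 and compound 3 show only that the series spans a narrow band. The step expected in this assay is therefore small, with a slight weakening somewhat more likely than a gain. Compound 4 is expected to give about 22000 nM in this assay, within a range from 8000 nM to 60000 nM. The expected step is a 1.5-fold higher number from compound 3 to compound 4 (0.19 log units; within the scatter).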

Compound 4, half-maximal inhibitory concentration: 93900 nM
For compound 4 the middle estimate is 4.3-fold (0.63 log units) below the measured one, and the stated range ends below it.
By their numbers in this assay, from the lowest: compound 3; then compounds 2 and 1 (each within the scatter of the next); then compound 4.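

Moving the fluorine on an otherwise unchanged ring is not a neutral change at this position in this assay: with the same atoms joined differently, the result is a 6.6-fold higher number from compound 3 to compound 4 (0.82 log units; beyond the scatter), a step beyond the scatter, so the identity of the atoms on the aniline ring does not alone set the number. Measured against the 3-ethynylphenyl group, the two chlorofluorophenyl isomers fall on opposite sides, with a 2.7-fold lower number from compound 1 to compound 3 (0.43 log units; beyond the scatter) for 3-chloro-4-fluorophenyl and a 2.4-fold higher number from compound 1 to compound 4 (0.39 log units; beyond the scatter) for 3-chloro-2-fluorophenyl, so the choice of isomer decides whether replacing 3-ethynylphenyl lowers or raises the number. Nothing available explains why the shift of the fluorine has this effect.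

On these data alone, it remains open whether the higher number of compound 4 goes with the fluorine at its new place or with the particular pairing of chlorine and fluorine, a question that a 3-chlorophenyl or a 2-fluorophenyl group on the same nitrogen would address. Also open, as far as these compounds go, is whether the same isomer step holds when the amide side of the molecule changes, for instance with a methoxy group on its phenyl ring or with a morpholine or a carboxylic acid in that region.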